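Pyrrolidinyl Replaces tert-Butyl on the Amide Carbonyl

The source may report more compounds than this note shows. Statements on the series, on what has been measured and on what is new or still open speak of the compounds shown alone.

Compound 1 `Cn1cncc1CN1CC(N(CC2CCN(C(=O)C(C)(C)C)CC2)S(=O)(=O)c2ccccn2)Cc2cc(C#N)ccc21` and compound 2 `CCC(=O)N1CCC(CN(C2Cc3cc(C#N)ccc3N(Cc3cncn3C)C2)S(=O)(=O)c2ccccn2)CC1` share the same core and differ only at the carbonyl on the piperidine nitrogen. In an ADME assay on Caco-2 cells (Homo sapiens) for permeability, in the apical to basolateral direction (on this read-out higher numbers stand for higher permeability and lower numbers for lower permeability), compound 1 gives 0.5 10^-6 cm/s, and compound 2 gives 0.5 10^-6 cm/s. The step of no change at the digits printed from compound 1 to compound 2 (within the scatter), ethyl in place of tert-butyl on a carbonyl carbon, brought no change beyond the scatter, so compound 1 stands level with compound 2 at the numbers shown.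

Compound 3 `Cn1cncc1CN1CC(N(CC2CCN(C(=O)N3CCCC3)CC2)S(=O)(=O)c2ccccn2)Cc2cc(C#N)ccc21` is the next member of the pair. Against compound 1 the change reads (pyrrolidin-1-yl in place of tert-butyl on a carbonyl carbon). Within the data shown here, the only measured step that bears on this position is no change at the digits printed from compound 1 to compound 2 (within the scatter), which also exchanged the group on that carbonyl carbon and left the read-out unchanged. Nothing in the data points to a direction for this further exchange, so the expected step from compound 1 to compound 3 in this assay is no change at the digits printed from compound 1 to compound 3 (within the scatter), no change beyond the scatter. Compound 3 is therefore expected to give about 0.5 10^-6 cm/s, within a range from 0.25 10^-6 cm/s to 1 10^-6 cm/s.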

Compound 3, apparent permeability: 0.6 10^-6 cm/s
For compound 3 the middle estimate is 1.2-fold (0.08 log units) below the measured one; the range from low to high includes it.
By their numbers in this assay, from the lowest: compounds 1, 2 and 3 (each within the scatter of the next).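

Up to this point, the only exchange on this carbonyl carbon had replaced one open carbon group with another. Pyrrolidin-1-yl brings in a five-membered non-aromatic ring with a nitrogen, and in this assay the result is a 1.2-fold higher number from compound 1 to compound 3 (0.08 log units; within the scatter) and, against the ethyl group, a 1.2-fold higher number from compound 2 to compound 3 (0.08 log units; within the scatter), so tert-butyl, ethyl and pyrrolidin-1-yl cannot be told apart on this read-out, whether the group is an open chain or a ring, and whether it holds only carbon or also a hetero atom. Nothing available here accounts for this flat result.

The compounds shown leave open whether a group of another kind on this carbonyl carbon, such as a primary amine, a carboxylic acid or a longer alkyl chain, would move the number beyond the scatter. They also leave open how the read-out responds to changes elsewhere, as all three compounds carry the rest of the shared core unaltered, including the nitrile and the sulfonyl group.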